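Shortening the Amide Chain on a Low-Toxicity Scaffold

A few compounds are considered here, and "the series" means these few. Any claim that something is new, unique, unknown or untested is made for them only; others in the source may bear on it.

Of the compounds shown here, three have been tested in a toxicity assay on THP-1 cells (Homo sapiens) for inhibition; on this read-out higher numbers stand for lower toxicity in this test and lower numbers for higher toxicity in this test. Compound 1, with the structure `CCC(=O)Nc1ncc(-c2ccc(OC)cc2)n1C`, reaches a limit of the test: in this assay compound 1 gives > 100000 nM, which is a limit rather than a measured number. Compound 2, `Cc1ccc(-c2cnc(NC(=O)c3ccc(F)cc3)n2C)cc1`, gives in this assay 60000 nM. Compound 3, `COc1ccc(-c2ccc(NC(=O)c3ccc(F)cc3)nc2)cc1`, also reaches a limit: in this assay compound 3 gives > 100000 nM, again a limit and not a number. Compound 1 therefore stands at the limit of > 100000 nM in this assay, at which 2 of the 3 values shown sit, together with compound 3, while compound 2 is the only one of the three with a number.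

Compound 4, `COc1ccc(-c2cnc(NC(C)=O)n2C)cc1`, has not yet been measured. It differs from compound 1 in a single place: hydrogen in place of methyl on a saturated chain carbon bound to a carbonyl carbon. No pair of measured compounds shares this change, so its size cannot be read from the data shown. The change removes one carbon from the amide chain and leaves the rest of the molecule as it is in compound 1, and the expected step that the limit leaves unreadable from compound 1 to compound 4 is none beyond the usual scatter. Compound 4 is expected to give about 150000 nM in this assay, within a range from 60000 nM to 400000 nM, and the test is expected most likely to report only a limit again.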

Compound 4, half-maximal cytotoxic concentration: > 100000 nM
Compound 4: a limit, no number; the forecaster's own chance of this, stated with the estimate: 75%; the middle value is on the limit's open side.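

In this assay compound 4 gives > 100000 nM, which is a limit and not a number. Among the compounds shown here, compound 1 also stands at a limit, so no step from propanoyl to acetyl can be read between compound 1 and compound 4. Most values now sit at one mark: the limit of > 100000 nM in this assay, at which 3 of the 4 values shown sit. The compounds shown leave open whether replacing propanoyl with acetyl changes toxicity in this test at all.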